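Sulfur-to-selenium exchange on the shared core

The source may report more compounds than this note shows. Statements on the series, on what has been measured and on what is new or still open speak of the compounds shown alone.

Measured so far in a functional assay on HT-29 cells (Homo sapiens) for cytotoxicity, read by MTT assay, with a stated time of 72 h; a lower number here means a stronger inhibitor of growth, a higher number a weaker inhibitor of growth:
compound 1 `CS/C(=N\C(=O)c1ccno1)NC(=O)c1ccno1` gives > 100000 nM.
compound 2 `C[Se]/C(=N\C(=O)c1ccco1)NC(=O)c1ccco1` gives 0.05 nM.
compound 3 `O=C(/N=C(/NC(=O)c1cc(-c2ccccc2)nc2ccccc12)[Se]Cc1ccccc1)c1cc(-c2ccccc2)nc2ccccc12` gives 6070 nM.

The value of compound 1 is a limit of this assay and not a number; it sits at the top of the figures shown (the limit of > 100000 nM in this assay, at which 1 of the 3 values shown sits). For the measured compounds named here, no two measured compounds differ in only one place, so no single step can be read from them; compound 2 and compound 3 simply show the values given. Compound 4 `C[Se]/C(=N\C(=O)c1ccno1)NC(=O)c1ccno1` is not yet measured. It differs from compound 1 by a group of 2 heavy atoms (1 carbon, 1 selenium; no ring) in place of a group of 2 heavy atoms (1 carbon, 1 sulfur; no ring), on a carbon with a double bond to nitrogen. The step from compound 1 to compound 4 in this assay is expected to be large, toward stronger inhibition, estimated as an at least 200-fold lower number from compound 1 to compound 4 (2.30 log units; beyond the scatter). For compound 4 the expected value in this assay is 500 nM, with a range of 5 nM to 50000 nM.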

Compound 4, concentration for 50% growth inhibition: 0.79 nM
Compound 4: middle estimate off by 630-fold (2.80 log units), on the high side; the measured number lies below the stated range.
By their numbers in this assay, from the lowest: compound 2; then compound 4; then compound 3. At a limit, above all of these: compound 1.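

In this assay, methylsulfanyl giving way to the group of carbon and selenium, on a carbon with a double bond to nitrogen, gives an at least 120000-fold lower number from compound 1 to compound 4 (5.10 log units; beyond the scatter). For the compounds shown here, this is the first single-place step, and it shows that this one exchange on the shared core can carry the whole difference between compound 1 and compound 4. The size is a bound and not an exact figure because compound 1 stands at a limit and not at a number: the limit of > 100000 nM in this assay, at which 1 of the 4 values shown sits.

Open, going by these compounds, is whether the exchange gives a step of like size on the core of compound 2. Also open, on these data alone, is whether a longer chain or an amine in place of the methyl on selenium keeps the value of compound 4.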